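The source may hold more compounds than are shown below. What is called first, only, known or untested is meant among the compounds shown, and "the series" means these compounds.

In a functional assay on MGC-803 cells (Homo sapiens) for inhibition, read by sulforhodamine B assay (a higher number here means a weaker inhibitor, a lower number a stronger inhibitor), compound 3 `CCCN(CCC)C1=CC(=O)c2nc3n(c2C1=O)[C@H]1OC[C@@H](O)[C@H]1OC3` gives > 16000 nM, which is a limit and not a number. Compound 1 `O=C1C=C(NC2CCCC2)C(=O)c2c1nc1n2[C@H]2OC[C@@H](O)[C@H]2OC1` gives > 8000 nM, which is also a limit. Compound 2 `O=C1C=C(Nc2ccc(Br)cc2)C(=O)c2c1nc1n2[C@H]2OC[C@@H](O)[C@H]2OC1` gives 1010 nM, a true measured number. Compound 4 `O=C1C=C(N2CCCCC2)C(=O)c2c1nc1n2[C@H]2OC[C@@H](O)[C@H]2OC1` carries piperidin-1-yl in place of dipropylamino on the same double-bonded ring carbon: piperidin-1-yl in place of dipropylamino on a double-bonded ring carbon. Within the data shown here, two measured steps bear on this change: an at least 15-fold higher number from compound 2 to compound 3 (1.19 log units; beyond the scatter), and an at least 7.9-fold lower number from compound 1 to compound 2 (0.89 log units; beyond the scatter). The third, a step that the two limits leave unreadable from compound 1 to compound 3, adds nothing. Like compound 3, compound 4 lacks the (4-bromophenyl)amino group of compound 2, so it is expected to stay weak given an at least 15-fold higher number from compound 2 to compound 3 (1.19 log units; beyond the scatter). The estimated step, in neither direction beyond the scatter, is a number no higher from compound 3 to compound 4 (the limit leaves the size open). The estimate for compound 4 is 16000 nM, with an expected range of 6000 nM to 45000 nM.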

Compound 4, half-maximal inhibitory concentration: > 8000 nM
Compound 4 was reported as a limit; the forecaster's own chance of this, stated with the estimate: 60%; the middle value lies beyond the limit too.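

In this assay, piperidin-1-yl in place of (4-bromophenyl)amino gives an at least 7.9-fold higher number from compound 2 to compound 4 (0.89 log units; beyond the scatter), so closing the nitrogen's substituents into a ring does not bring back the activity of compound 2. Compound 4 is reported only as a limit, and its steps to compound 1 and compound 3 cannot be read, so the ring and the open dipropylamino chain cannot be ranked. Of the compounds shown, only compound 2, with an aromatic ring on the amine nitrogen, gives a true number.

On these data alone, whether that activity needs the bromine or only the phenyl ring stays open. Plain phenylamino or (4-methoxyphenyl)amino at this carbon could separate the two.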